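Cyclohexyl in place of methyl on the pyridin-4-yl compound

The compounds below may be only part of what the source reports. "The series", "measured", "known", "first", "only" and "open" are said of these compounds alone.

In a functional assay on A549 cells (Homo sapiens) for antiproliferative activity, read by CCK-8 assay, with a stated time of 48 h (a lower number here means a stronger inhibitor, a higher number a weaker inhibitor), compound 1 (`CNC(=O)c1cc(Oc2ccc(/C=C/c3ccccn3)cc2)ccn1`) gives 17400 nM, compound 2 (`O=C(NC1CCCCC1)c1cc(Oc2ccc(/C=C/c3ccccn3)cc2)ccn1`) gives 12500 nM and compound 3 (`CNC(=O)c1cc(Oc2ccc(/C=C/c3ccncc3)cc2)ccn1`) gives 13200 nM. Compound 3 therefore stands within the scatter of both other compounds, and the three numbers show no order among them.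

The next compound is compound 4 (`O=C(NC1CCCCC1)c1cc(Oc2ccc(/C=C/c3ccncc3)cc2)ccn1`). The change is cyclohexyl in place of methyl on an amide-type nitrogen. The same exchange has one measured precedent, a 1.4-fold lower number from compound 1 to compound 2 (0.14 log units; within the scatter), which lies within the scatter. The other measured step, a 1.3-fold lower number from compound 1 to compound 3 (0.12 log units; within the scatter), is the pyridin-4-yl for pyridin-2-yl exchange, also within the scatter, and it shows that the same amide exchange now starts from a closely similar value. No step beyond the scatter is therefore expected in this assay, with only a slight lean towards a lower number.

The expected step is a 1.3-fold lower number from compound 3 to compound 4 (0.12 log units; within the scatter). For compound 4 the estimated value is 10000 nM, with an expected range of 6000 nM to 17000 nM.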

Compound 4, half-maximal inhibitory concentration: 16800 nM
Compound 4: middle estimate off by 1.7-fold (0.23 log units), on the low side; the range from low to high includes it.
By their numbers in this assay, from the lowest: compounds 2, 3, 4 and 1 (each within the scatter of the next).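

In this assay, each of the two exchanges now has a second reading on a different core: cyclohexyl for methyl on the amide-type nitrogen gives a 1.3-fold higher number from compound 3 to compound 4 (0.10 log units; within the scatter), and pyridin-4-yl for pyridin-2-yl gives a 1.3-fold higher number from compound 2 to compound 4 (0.13 log units; within the scatter). The two readings of the amide exchange agree within the scatter, so the four compounds show no effect of this change that can be told from the scatter: the same change on two cores in this assay, a 1.4-fold lower number (0.14 log units; within the scatter) from compound 1 to compound 2 and a 1.3-fold higher number (0.10 log units; within the scatter) from compound 3 to compound 4, 1.8-fold (0.25 log units) apart, within the scatter of two such steps. The same holds for the pyridin-4-yl for pyridin-2-yl exchange: the same change on two cores in this assay, a 1.3-fold lower number (0.12 log units; within the scatter) from compound 1 to compound 3 and a 1.3-fold higher number (0.13 log units; within the scatter) from compound 2 to compound 4, 1.8-fold (0.25 log units) apart, within the scatter of two such steps.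

Open, on these data alone, is whether any group at these two places moves the number beyond the scatter. Candidates are a benzyl group or an aminoethyl chain on the amide-type nitrogen, and pyridin-3-yl in place of pyridin-4-yl.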